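Removing the core methoxy: a single step to compound 4

The source may report more compounds than this note shows. Statements on the series, on what has been measured and on what is new or still open speak of the compounds shown alone.

Measured compounds:
Compound 1, `COc1cc(Br)cc2c1OC(N)=C(C#N)C2CC(=O)c1ccccc1`, 45.9%
Compound 2, `COc1cc(Br)cc2c1OC(N)=C(C#N)C2CC(=O)c1ccc(Cl)cc1`, 41.6%
Compound 3, `COc1cccc(C(=O)CC2C(C#N)=C(N)Oc3c(OC)cc(Br)cc32)c1`, 46.3%

In an ADME assay on MCF-10A cells (Homo sapiens) for cytotoxicity, read by sulforhodamine B assay, with a stated time of 72 h, tested at 30 uM (a higher number here means a stronger effect of the compound at the concentration tested, a lower number a weaker effect), compound 3 gives 46.3%, the highest of the three numbers, although its nearest neighbour compound 1 lies only a number 0.4 percentage points higher from compound 1 to compound 3 (within the scatter) and compound 2 lies a number 4.7 percentage points higher from compound 2 to compound 3 (within the scatter); all three compounds therefore sit within the scatter of one another, and none can be called the strongest.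

Compound 4, `COc1cccc(C(=O)CC2C(C#N)=C(N)Oc3ccc(Br)cc32)c1`, differs from compound 3 in one place: hydrogen in place of methoxy on an aromatic carbon. Among the measured compounds shown here, the change sits on the shared core rather than on the aryl ketone, so no measured step copies it exactly. The closest step in kind is the one in which a methoxy group is gained rather than lost, giving a number 0.4 percentage points higher from compound 1 to compound 3 (within the scatter). The other two steps, a number 4.3 percentage points lower from compound 1 to compound 2 (within the scatter) and a number 4.7 percentage points higher from compound 2 to compound 3 (within the scatter), were likewise within the scatter. From this the writer expects no step beyond the scatter in this assay for compound 4, in no particular direction.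

The estimated step is a number 2.3 percentage points lower from compound 3 to compound 4 (within the scatter). Compound 4 is expected to give about 44%, between 30% and 58%.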

Compound 4, a percentage reported as activity, at one concentration (the size of the read-out at that concentration, not a potency): 43.7%
The estimate for compound 4 lay 0.3 percentage points above the measured number; the measured number falls inside the stated range.
By their numbers in this assay, from the lowest: compounds 2, 4, 1 and 3 (each within the scatter of the next).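

In this assay, the loss of the methoxy from the aromatic carbon of the shared core gives a number 2.6 percentage points lower from compound 3 to compound 4 (within the scatter). The earlier steps shown here all lay on the aryl ketone, whereas this one lies on the core, ortho to a fused ring and meta to a bromo group, and it shows that hydrogen and methoxy at this position give numbers within the scatter of each other, with the aryl ketone held as 3-methoxyphenyl. No evidence is at hand that bears on the reason for this result.

With only hydrogen and methoxy seen at this position, the compounds shown leave open whether a hydroxyl, an amine or a longer alkoxy chain such as butoxy would give a step beyond the scatter. Also open, on these data alone, are whether a chloro group or a carboxylic acid in place of the bromo group on the core would do so, and whether the phenyl and 4-chlorophenyl ketones would read as they do here once the core methoxy is replaced by hydrogen.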